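Swapping phenyl for pyridin-2-yl on the cyclopropane ring

The compounds below may be only part of what the source reports. "The series", "measured", "known", "first", "only" and "open" are said of these compounds alone.

Measured compounds:
compound 1 `CC[C@H](C)[C@H](N)CN(C(=O)[C@@H]1C[C@H]1c1ccccn1)c1ccc(-c2ccccc2)cc1`, 130 nM
compound 2 `CCc1ccc(-c2ccc(N(C[C@@H](N)[C@@H](C)CC)C(=O)[C@@H]3C[C@H]3c3ccccc3)cc2)cc1`, 44 nM
compound 3 `CC[C@H](C)[C@H](N)CN(C(=O)[C@@H]1C[C@H]1c1ccccc1)c1ccc(-c2ccc(COC)cc2)cc1`, 35 nM

All three were tested in a functional assay for agonist activity at G protein-coupled receptor 88 (Homo sapiens), read by HTRF and cAMP accumulation; a higher number here means that more compound is needed for the effect, a lower number that less compound is needed. Compound 3 gives the lowest number of the three; its step to compound 2 lies within the scatter, while compound 1 gives a number beyond the scatter above it.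

The unmeasured compound 4 `CC[C@H](C)[C@H](N)CN(C(=O)[C@@H]1C[C@H]1c1ccccn1)c1ccc(-c2ccc(COC)cc2)cc1` differs from compound 3 in one place: pyridin-2-yl in place of phenyl on a saturated ring carbon. Within the data shown here, no measured step covers exactly this swap. The only single-point step shown, a 1.3-fold lower number from compound 2 to compound 3 (0.10 log units; within the scatter), concerns a different part of the molecule. Compound 1 carries the pyridin-2-yl and compound 3 the phenyl, but they also differ at the distant methoxymethyl group, so their values cannot be attributed to the ring swap alone; they only show that compound 1 gives 130 nM and compound 3 gives 35 nM.

With this limited footing, the estimate for compound 4 is 75 nM, within 25 nM to 220 nM. This means an expected step of a 2.1-fold higher number from compound 3 to compound 4 (0.33 log units; beyond the scatter), a modest weakening that may still fall inside the scatter.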

Compound 4, half-maximal effective concentration: 15 nM
Beside the measured number, compound 4's estimate is 5.0-fold (0.70 log units) above it; measured number below the stated range.
By their numbers in this assay, from the lowest: compound 4; then compounds 3 and 2 (each within the scatter of the next); then compound 1.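

In this assay, the swap of phenyl for pyridin-2-yl on the saturated ring carbon can now be read by itself, and it gives a 2.3-fold lower number from compound 3 to compound 4 (0.37 log units; beyond the scatter); the exchange keeps the heavy-atom count but adds a ring nitrogen and one hydrogen-bond acceptor. The pair of compound 1 and compound 4 also isolates a second change, methoxymethyl in place of hydrogen on an aromatic carbon, which gives an 8.7-fold lower number from compound 1 to compound 4 (0.94 log units; beyond the scatter), so the pyridin-2-yl group is compatible with a low number here and the high number of compound 1 cannot be charged to that ring. No measured evidence explains either step, so the reason for these changes in the number remains unknown.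

The compounds shown leave open whether pyridin-3-yl, pyridin-4-yl or pyrimidin-2-yl on the same ring carbon would give a similar step, which would show whether the placement of the ring nitrogen matters. On these data alone, it also remains open whether the swap from phenyl to pyridin-2-yl gives a step of similar size when the methoxymethyl group is replaced by hydrogen or ethyl.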